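The source may report more compounds than this note shows. Statements on the series, on what has been measured and on what is new or still open speak of the compounds shown alone.

In a functional assay on SW1573 cells (Homo sapiens) for antiproliferative activity, read by sulforhodamine B assay, with a stated time of 48 h (a higher number here means a weaker inhibitor of growth, a lower number a stronger inhibitor of growth), compound 1 `CC(C)(C)[Si](C)(C)O[C@@H]1CCCO[C@@H]1COCC(=O)O` gives > 100000 nM, a limit of the assay and not a number. It therefore stands at the limit of > 100000 nM in this assay, at which 2 of the 3 values shown sit. Compound 2 `CC(C)(C)[Si](C)(C)O[C@@H]1CCCO[C@@H]1COCC(=O)OCc1ccccc1`, its benzyl ester, gives 29000 nM. Without the silyl group, compound 3 `O=C(COC[C@H]1OCCC[C@@H]1O)OCc1ccccc1` gives > 100000 nM, also a limit of the assay and not a number.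

Compound 4 `CC(C)(C)[Si](C)(C)O[C@@H]1CCCO[C@@H]1CO/C=C/CO` keeps the silyl group and the core of compound 1, and the change lies in the chain: 3-hydroxyprop-1-en-1-yl in place of carboxymethyl on an oxygen on a saturated carbon. Within the data shown here, the one measured step that bears on this is an at least 3.4-fold lower number from compound 1 to compound 2 (0.53 log units; beyond the scatter). That step also alters the carboxymethyl end, although it keeps the carbonyl, whereas compound 4 loses it, so it is only a loose guide. A step of similar size toward a lower number is therefore expected, and the estimate is an at least 2.2-fold lower number from compound 1 to compound 4 (0.34 log units; beyond the scatter). A reading at the limit would not be surprising. For compound 4, the expected value is 45000 nM, with an estimated range of 15000 nM to 100000 nM.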

Compound 4, concentration for 50% growth inhibition: > 100000 nM
Compound 4 was reported as a limit; the forecaster's own chance of this, stated with the estimate: 35%; middle value at least 2.2-fold (0.34 log units) away from the limit.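

In this assay, among these compounds, compound 1 and compound 4 both stand at a limit and not at a number, so no step between them can be read: the limit of > 100000 nM in this assay, at which 3 of the 4 values shown sit.

The compounds shown leave open whether 3-hydroxyprop-1-en-1-yl in place of carboxymethyl changes growth inhibition at all, and in which direction.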